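Swapping the ketone-side ring in an enone series

The source may hold more compounds than are shown below. What is called first, only, known or untested is meant among the compounds shown, and "the series" means these compounds.

Measured so far:
- compound 1, `COc1ccc(C(=O)/C=C/c2cn(-c3ccccc3)nc2-c2ccsc2)c(OC)c1OC`: 4200 nM
- compound 2, `COc1ccc(OC)c(C(=O)/C=C/c2cn(-c3ccccc3)nc2-c2ccsc2)c1`: 2100 nM
- compound 3, `O=C(/C=C/c1cn(-c2ccccc2)nc1-c1cccnc1)c1cc[nH]c1`: 3300 nM

All three compounds share the same enone-linked core and were tested in a functional assay on Huh-7 cells (Homo sapiens) for inhibition, read by sulforhodamine B assay, with a stated time of 72 h; on this read-out lower numbers stand for stronger inhibition and higher numbers for weaker inhibition. Compound 3 sits second highest of the three numbers. Its nearest neighbour is compound 1, which gives 4200 nM, a gap within the usual scatter; the furthest is compound 2, which gives 2100 nM, also within the scatter. So the three measured compounds cannot be ranked against one another with confidence.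

Compound 4, `COc1ccc(OC)c(C(=O)/C=C/c2cn(-c3ccccc3)nc2-c2cccnc2)c1`, has not yet been measured. It differs from compound 3 in one place: 2,5-dimethoxyphenyl in place of 1H-pyrrol-3-yl on a carbonyl carbon. For the measured compounds named here, no measured pair describes this exact change, so its effect has to be judged from the spread of the numbers already in hand.

Compound 2 carries the same 2,5-dimethoxyphenyl on the carbonyl carbon and gives 2100 nM, which suggests that compound 4 will land in the same region as the measured set. The step from compound 3 to compound 4 is therefore expected to be small, a 1.3-fold lower number from compound 3 to compound 4 (0.12 log units; within the scatter), not clearly beyond the scatter in either direction. Compound 4 is estimated at 2500 nM, with a range from 1000 nM to 6000 nM.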

Compound 4, half-maximal inhibitory concentration: 1300 nM
Estimate against measurement, compound 4: 1.9-fold (0.28 log units) above, and the stated range covers the measured number.
By their numbers in this assay, from the lowest: compounds 4, 2, 3 and 1 (each within the scatter of the next, the first and the last beyond it).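

In this assay, for the compounds shown here, 2,5-dimethoxyphenyl in place of 1H-pyrrol-3-yl on a carbonyl carbon gives a 2.5-fold lower number from compound 3 to compound 4 (0.40 log units; beyond the scatter) as its step, the first measured change in this set that lies beyond the scatter, so the group at this place can shift the number, if only modestly. The second change, pyridin-3-yl in place of thiophen-3-yl on an aromatic carbon, gives a 1.6-fold lower number from compound 2 to compound 4 (0.21 log units; within the scatter) and stays within the scatter, so with 2,5-dimethoxyphenyl on the carbonyl carbon these two rings cannot be told apart on this read-out. Nothing at hand offers a measured explanation for either step.

The step from the pyrrole to the dimethoxyphenyl swaps ring size, removes a hydrogen-bond donor and brings in hydrogen-bond acceptors all at once, so the compounds shown cannot say which of these differences matters. A plain phenyl on the carbonyl carbon, or a ring carrying a single methoxy group or an amine, would be needed to begin separating them.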